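This account rests on a few compounds, and the source may have more. Where it says the series, first, only, none or still open, it means among the compounds named here.

Among the measured compounds shown here, compound 1, `Oc1cccc(-c2cc(-c3ccc(F)cc3)cc(-c3cccc(O)c3)n2)c1`, and compound 2, `Oc1cccc(-c2cc(-c3ccc(OC(F)(F)F)cc3)cc(-c3ccccc3O)n2)c1`, are the two compounds measured so far. In a functional assay on HeLa cells (Homo sapiens) for inhibition (on this read-out lower numbers stand for stronger inhibition and higher numbers for weaker inhibition), compound 1 gives 1280 nM. In this assay compound 2 gives 20600 nM, the higher of the two numbers, and its gap to compound 1 lies beyond the usual scatter of repeated measurements. Compound 3, `Oc1cccc(-c2cc(-c3ccc(OC(F)(F)F)cc3)cc(-c3cccc(O)c3)n2)c1`, has not yet been measured. It differs from compound 2 in one place: 3-hydroxyphenyl in place of 2-hydroxyphenyl on an aromatic carbon. The two compounds share every atom and differ only in how the hydroxyl is placed on that phenyl ring. Since compound 1, which carries a 3-hydroxyphenyl group at the corresponding position, gives 1280 nM, the change is expected to lower the number, with an expected step of a 10-fold lower number from compound 2 to compound 3 (1.01 log units; beyond the scatter) from compound 2 to compound 3. For compound 3 the value in this assay is estimated at 2000 nM, with a likely range from 600 nM to 7000 nM.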

Compound 3, half-maximal inhibitory concentration: 18700 nM
Compound 3: the middle estimate sits 9.4-fold (0.97 log units) below what was measured; measured number outside the range, above it.
By their numbers in this assay, from the lowest: compound 1; then compounds 3 and 2 (each within the scatter of the next).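

With the trifluoromethoxy group in place, the 3-hydroxyphenyl and 2-hydroxyphenyl groups on this aromatic carbon cannot be told apart in this assay, which gives a 1.1-fold lower number from compound 2 to compound 3 (0.04 log units; within the scatter). By contrast, trifluoromethoxy in place of fluoro, with the 3-hydroxyphenyl group kept, gives a 15-fold higher number from compound 1 to compound 3 (1.16 log units; beyond the scatter), so in this pair the large step goes with that exchange and not with where the hydroxyl sits. Nothing at hand accounts for either step.

The compounds shown leave open whether the placement of the hydroxyl would also make no readable difference with fluoro on the compound. They also leave open how a methoxy group, a chloro group or an amine would read at the place held by fluoro and trifluoromethoxy.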